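The source may report more compounds than this note shows. Statements on the series, on what has been measured and on what is new or still open speak of the compounds shown alone.

Compound 1 `O=C1C=COC(/C=C/c2ccccc2)C1` is the parent of this set. In a functional assay on 786-0 cells (Homo sapiens) for inhibition, read by sulforhodamine B assay, with a stated time of 48 h (on this read-out lower numbers stand for stronger inhibition of growth and higher numbers for weaker inhibition of growth), compound 1 gives 138 uM. Compound 2 `COc1ccc(/C=C/C2CC(=O)C=CO2)cc1` differs from it by methoxy in place of hydrogen on an aromatic carbon, and in this assay compound 2 gives 192 uM, so that a 1.4-fold higher number from compound 1 to compound 2 (0.14 log units; within the scatter). Compound 3 `COc1ccc(/C=C/C2CC=CC(=O)N2)cc1` rests on another core; the difference between the two cores is not broken down here. In this assay compound 3 gives only a limit, > 1090 uM. This is the limit of > 1090 uM in this assay, at which 1 of the 3 values shown sits, so no number exists for compound 3.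

Compound 4 `COc1ccc(/C=C/C2CC=CC(=O)N2)c(OC)c1` is to be measured in this assay and differs from compound 3 by methoxy in place of hydrogen on an aromatic carbon. For the measured compounds named here, this is the same kind of change as the one from compound 1 to compound 2, not the same: in compound 2 the methoxy stands para to a group of 9 heavy atoms, in compound 4 ortho to a group of 9 heavy atoms and meta to a methoxy group. Since the earlier step of a 1.4-fold higher number from compound 1 to compound 2 (0.14 log units; within the scatter) stayed within the scatter, the step that the limit leaves unreadable from compound 3 to compound 4 is expected to be small as well. Starting from a limit, compound 4 is therefore expected to give about 1500 uM, between 500 uM and 5000 uM, most likely again only a limit.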

Compound 4, concentration for growth inhibition (reported as GI): > 964 uM
Compound 4 gave a limit, no number; the forecaster's own chance of this, stated with the estimate: 75%; the middle value does not contradict the limit.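

Compound 3 gives > 1090 uM in this assay, which is a limit and not a number. For the compounds shown here, compound 4 gives > 964 uM in the same assay, also a limit, so no step from compound 3 to compound 4 can be read. The compounds shown leave open whether methoxy in place of hydrogen on an aromatic carbon changes growth inhibition on this core at all.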